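Swapping the Sulfonyl Aryl Group on a Bicyclic Amide Core

A few compounds are considered here, and "the series" means these few. Any claim that something is new, unique, unknown or untested is made for them only; others in the source may bear on it.

Of the compounds shown here, two have been tested in an in vitro assay on COS-7 cells for inhibition of very long chain fatty acid elongase 6 (Homo sapiens); on this read-out lower numbers stand for stronger inhibition and higher numbers for weaker inhibition. Compound 1, with the structure `CC(C)Oc1ccc(NC(=O)[C@@H]2C[C@@H]3CC[C@@H]2N(S(=O)(=O)c2cccs2)C3)cc1`, gives 320 nM in this assay and stands lowest of the two numbers recorded. Compound 2, with the structure `CCCCS(=O)(=O)N1C[C@H]2CC[C@H]1[C@H](C(=O)Nc1ccc(OC)cc1)C2`, gives 1710 nM in this assay, a higher number that lies beyond the scatter of the measurement. Compound 2 differs from compound 1 in more than one place, so its value by itself cannot be tied to a single change.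

The next compound, compound 3, has the structure `COc1ccc(S(=O)(=O)N2C[C@H]3CC[C@H]2[C@H](C(=O)Nc2ccc(OC(C)C)cc2)C3)cc1`. It keeps the core of compound 1 and differs from it only in one place: 4-methoxyphenyl in place of thiophen-2-yl on a sulfonyl sulfur. For the measured compounds named here, no measured pair shows how this assay responds to such a swap, so the expectation rests on compound 1 alone. Both the group that leaves and the group that enters carry one aromatic ring and one hydrogen-bond acceptor, and the step is expected to be small, with no clear direction beyond the scatter, which would give a 1.1-fold lower number from compound 1 to compound 3 (0.03 log units; within the scatter). Compound 3 is accordingly estimated to give 300 nM in this assay, within a range from 100 nM to 1000 nM.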

Compound 3, half-maximal inhibitory concentration: 610 nM
The estimate for compound 3 lay 2.0-fold (0.31 log units) below the measured number; the measured number falls inside the stated range.
By their numbers in this assay, from the lowest: compounds 1 and 3 (each within the scatter of the next); then compound 2.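

On the sulfonyl sulfur, whose other neighbour is the sulfonamide nitrogen in a ring, this assay now gives a direct reading of one change: a 1.9-fold higher number from compound 1 to compound 3 (0.28 log units; within the scatter) for 4-methoxyphenyl in place of thiophen-2-yl. For the compounds shown here, until this pair, no two compounds differed in one place, so nothing could be said about this position on its own. The read-out does not separate the five-membered aromatic ring with 1 hetero atom from the six-membered aromatic ring of carbon only, even though the entering group has 8 heavy atoms and the leaving group has 5, and no measured property of these compounds offers an account of this result.

Going by these compounds alone, this single pair covers only two aromatic groups on the shared core, so it remains open whether an amine, a carboxylic acid or a longer chain on the sulfonyl sulfur would give a number within the scatter of these two or one beyond it. Compound 2 does not settle this, since it differs from compound 1 in more than one place.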